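Replacing a Pyrrolidine Amide with a Hydroxymethylpiperidine Amide

The source may report more compounds than this note shows. Statements on the series, on what has been measured and on what is new or still open speak of the compounds shown alone.

Compound 1, `O=C(NCc1cccc(Cl)c1)c1ccc2cn(CCN3CCOC3=O)nc2c1`, gives 220 nM.
Compound 2, `CCCc1cc(C(=O)N(CCC)CC2CCOC2)cc2nc(NCc3cccc(Cl)c3)oc12`, gives 957 nM.
Compound 3, `COc1cc(C(=O)N2CCCC2)cc2nc(NCc3cccc(Cl)c3)oc12`, gives 180 nM.

These three compounds were tested in an assay on isolated protein for inhibition of thyroid hormone receptor beta (Homo sapiens), read by fluorescence, with a stated time of 30 min; on this read-out lower numbers stand for stronger inhibition and higher numbers for weaker inhibition. Compound 3 has the lowest number of the three; its gap to compound 1 lies within the usual scatter of this measurement, so the two cannot be ranked, while compound 2 stands well beyond the scatter with a clearly higher number.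

Compound 4, `COc1cc(C(=O)N2CC[C@H](O)[C@@H](C)C2)cc2nc(NCc3cccc(Cl)c3)oc12`, is not yet measured. It differs from compound 3 in one place: 4-hydroxy-3-methylpiperidin-1-yl in place of pyrrolidin-1-yl on a carbonyl carbon. For the measured compounds named here, no pair of measured compounds isolates this change, so there is no directly comparable step to lean on. The only other variation of the amide group, seen in compound 2, goes with a clearly higher number, but compound 2 also differs in other places, so it is not a clean guide.

For compound 4 a modest step toward a higher number is expected, a 1.8-fold higher number from compound 3 to compound 4 (0.25 log units; within the scatter), though the range is wide enough to include no change beyond the scatter. The estimate for compound 4 is 320 nM, between 110 nM and 950 nM.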

Compound 4, half-maximal inhibitory concentration: 120 nM
Estimate against measurement, compound 4: 2.7-fold (0.43 log units) above; measured number inside the range.
By their numbers in this assay, from the lowest: compounds 4, 3 and 1 (each within the scatter of the next); then compound 2.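

In this assay, exchanging pyrrolidin-1-yl for 4-hydroxy-3-methylpiperidin-1-yl on a carbonyl carbon gives a 1.5-fold lower number from compound 3 to compound 4 (0.18 log units; within the scatter) and so leaves the two compounds unranked. For the compounds shown here, this is the first clean reading at this position: a larger six-membered ring carrying a hydrogen-bond donor and acceptor and two defined stereocentres is accepted here with no change beyond the scatter. Nothing at hand explains why the number holds.

The result cannot show whether the hydroxyl, the methyl, the stereochemistry or the ring size matters, since the new group changes all of them at once. A plain piperidin-1-yl, a morpholin-4-yl or the other stereoisomers of the new group on the same carbonyl carbon would help separate these contributions.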